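Two ring stereocentres inverted in a peroxide acid

The source may report more compounds than this note shows. Statements on the series, on what has been measured and on what is new or still open speak of the compounds shown alone.

The study measures cytotoxicity in a functional assay on IGRO cells (Homo sapiens) for cytotoxicity, read by colony formation; on this read-out lower numbers stand for stronger inhibition of growth and higher numbers for weaker inhibition of growth. Three compounds carry numbers or a limit there. Compound 1 `C=C1CCCC(C)(C)C1CC[C@]1(C)CC[C@@H]([C@@H](C)C(=O)O)OO1` gives 1730 nM in this assay, the highest of the two numbers recorded. Compound 2 `C=C1CCC[C@@H]2[C@@H](CC[C@@]3(C)CC[C@H]([C@H](C)C(=O)O)OO3)[C@H](C)CC[C@@]12C` gives 100 nM in this assay, a step beyond the usual scatter and the nearest value to compound 1. Compound 3 `CC1=C(CC/C(C)=C/CC[C@@]2(C)CC[C@@H]([C@H](C)C(=O)O)OO2)C(C)(C)CCC1` is reported only as a limit of this assay, > 5000 nM, which matches the limit of > 5000 nM in this assay, at which 1 of the 3 values shown sits, and stands for no number.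

Compound 4 `C=C1CCCC(C)(C)C1CC[C@@]1(C)CC[C@H]([C@@H](C)C(=O)O)OO1` is the compound not yet measured. It differs from compound 1 as follows: the two compounds have the same atoms and bonds; at least one stereo element is drawn with a configuration in one of them and without one in the other: 2 of 4 stereo elements differ; a stereocentre at a saturated ring carbon is drawn R in compound 1 and S in compound 4; a stereocentre at a saturated ring carbon is drawn S in compound 1 and R in compound 4. Going by the values given here, no step between two measured compounds traces this kind of change, so the size of its effect is not known from the data here. The two inversions are expected to move the value in this assay by no more than the change a 1.2-fold lower number from compound 1 to compound 4 (0.06 log units; within the scatter), with the direction left open. Compound 4 is therefore estimated at 1500 nM in this assay, within a range from 400 nM to 6000 nM.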

Compound 4, concentration for 50% growth inhibition: 630 nM
Compound 4: middle estimate off by 2.4-fold (0.38 log units), on the high side, and the stated range covers the measured number.
By their numbers in this assay, from the lowest: compound 2; then compound 4; then compound 1. At a limit, above all of these: compound 3.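

In this assay, inverting the two saturated ring stereocentres, with atoms and bonds unchanged, gives a 2.7-fold lower number from compound 1 to compound 4 (0.44 log units; beyond the scatter). Going by these compounds alone, the step is modest but beyond the usual scatter, and it shows that configuration at these two ring carbons alone can shift growth inhibition, which the earlier compounds could not show because no measured pair among them differed in one place. One caution applies to reading this step: the fact that one of compounds 1 and 4 is drawn with a defined configuration and the other without, at the place where they differ

Going by these compounds, it remains open how much of the step belongs to each stereocentre alone, and whether the same inversion would have a similar effect on the core of compound 2. Also open, on these data alone, is how a methyl ester or a primary amide in place of the carboxylic acid would read out with either configuration.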